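This account rests on a few compounds, and the source may have more. Where it says the series, first, only, none or still open, it means among the compounds named here.

Measured compounds in an assay on microsomes from liver for inhibition of sterol O-acyltransferase 1 (Rattus norvegicus); a higher number here means a weaker inhibitor, a lower number a stronger inhibitor:

compound 1, `C[C@@]1(O)CC(=O)OC(CSc2nc(-c3ccccc3)c(-c3ccccc3)[nH]2)C1`: compound 1 gives 170 nM
compound 2, `C[C@@]1(O)CC(=O)OC(CSc2nc(-c3ccc(Cl)cc3)c(-c3ccc(Cl)cc3)[nH]2)C1`: compound 2 gives 180 nM
compound 3, `CC1=CC(=O)OC(CSc2nc(-c3ccccc3Cl)c(-c3ccccc3Cl)[nH]2)C1`: compound 3 gives 1700 nM

Compound 1 sits at the low end of the three numbers in this assay, together with compound 2, whose value lies within the scatter of that of compound 1. Compound 3 stands apart with a clearly higher number, beyond the scatter.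

The next compound, compound 4, `c1ccc(-c2nc(SCC3CCCCO3)[nH]c2-c2ccccc2)cc1`, is reached from compound 1 by one change: a group of 6 heavy atoms (5 carbon, 1 oxygen; one six-membered non-aromatic ring with 1 hetero atom) in place of a group of 9 heavy atoms (6 carbon, 3 oxygen; one six-membered non-aromatic ring with 1 hetero atom), on a saturated chain carbon bound to a sulfur. The shared core of compound 1 and the two unsubstituted phenyl rings are kept. Within the data shown here, no measured pair in this set isolates this change, so nothing in the data quantifies it directly. Given that the part removed carries the only hydrogen-bond donor and two of the acceptors that compound 1 has in this region, a shift toward a higher number in this assay is expected, of a size exceeding the scatter but well short of the gap to compound 3. The step from compound 1 to compound 4 is estimated at a 2.6-fold higher number from compound 1 to compound 4 (0.42 log units; beyond the scatter). Compound 4 is therefore expected to give about 450 nM, in a range from 130 nM to 1600 nM.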

Compound 4, half-maximal inhibitory concentration: 210 nM
The estimate for compound 4 lay 2.1-fold (0.33 log units) above the measured number, and the stated range covers the measured number.
By their numbers in this assay, from the lowest: compounds 1, 2 and 4 (each within the scatter of the next); then compound 3.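

In this assay, oxan-2-yl in place of the group of 9 heavy atoms, on a saturated chain carbon bound to a sulfur, gives a 1.2-fold higher number from compound 1 to compound 4 (0.09 log units; within the scatter). At this position, with the two unsubstituted phenyl rings kept, the number therefore stays within the scatter even though the group that leaves has 1 hydrogen-bond donor, 3 hydrogen-bond acceptors and 1 defined stereocentre, and oxan-2-yl has 0 donors and 1 acceptor. No measurement shown here accounts for this result.

On these data alone, whether oxan-2-yl gives the same outcome with the chlorine-bearing phenyl rings of compound 2 remains open. So does the effect of an amine, a carboxylic acid or a longer chain at this place.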